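A few compounds are considered here, and "the series" means these few. Any claim that something is new, unique, unknown or untested is made for them only; others in the source may bear on it.

Compound 3 `Cc1cccc(/C(N)=N/NC(=S)N2CCOCC2)n1` sits at the top of the numbers seen so far in a functional assay on A-431 cells (Homo sapiens) for cytotoxicity, read by MTT assay, with a stated time of 72 h, tested at 30 uM (a lower number here means less inhibition of growth, a higher number more inhibition of growth at the concentration tested), where compound 3 gives 80%; compound 2 `N/C(=N\NC(=S)N1CCCCC1)c1ccccn1` gives 79.7% in the same assay, and compound 1 `Cc1cccc(/C(N)=N/NC(=S)N2CCSCC2)n1` gives 64.5%. The step from compound 1 to compound 3 a number 15.5 percentage points higher from compound 1 to compound 3 (beyond the scatter) shows that the ring on the thiocarbonyl carbon moves the read-out. Compound 4 `Cc1cccc(/C(N)=N/NC(=S)N2CCCCC2)n1` carries piperidin-1-yl in place of morpholin-4-yl on a thiocarbonyl carbon. Among the compounds with values here, no measured step covers this exact exchange; compound 2 also carries piperidin-1-yl, on a different core, so its value is the closest guide. For compound 4 a modest downward step a number 6 percentage points lower from compound 3 to compound 4 (within the scatter) is expected, giving an estimated 74% in this assay, with a range from 58% to 88%.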

Compound 4, percent growth inhibition at one concentration: 65.2%
Estimate against measurement, compound 4: 8.8 percentage points above, and the stated range covers the measured number.
By their numbers in this assay, from the lowest: compounds 1 and 4 (each within the scatter of the next); then compounds 2 and 3 (each within the scatter of the next).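

With the methyl-bearing core held, a number 14.8 percentage points lower from compound 3 to compound 4 (beyond the scatter) in this assay separates morpholin-4-yl from piperidin-1-yl, while a number 0.7 percentage points higher from compound 1 to compound 4 (within the scatter) leaves piperidin-1-yl and thiomorpholin-4-yl together. Methyl in place of hydrogen on an aromatic carbon, with piperidin-1-yl held, gives a number 14.5 percentage points lower from compound 2 to compound 4 (beyond the scatter) and so makes compound 2 a poor guide to this core. No evidence on the cause of these steps is at hand. Going by these compounds, whether a piperazin-1-yl ring or an open-chain dimethylamino group on the thiocarbonyl carbon would match morpholin-4-yl stays open. Also open, on these data alone, is whether methyl in place of hydrogen gives a similar step with morpholin-4-yl held.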